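Moving the hydroxy group on the piperidine ring

This account rests on a few compounds, and the source may have more. Where it says the series, first, only, none or still open, it means among the compounds named here.

Measured in a functional assay on HL-60 cells (Homo sapiens) for cytotoxicity, read by MTT assay, with a stated time of 72 h; on this read-out higher numbers stand for weaker inhibition and lower numbers for stronger inhibition:
Compound 1 `COc1ccc(S(=O)(=O)c2nc3ccccc3nc2N2CCc3ccccc3C2)cc1`: 3690 nM
Compound 2 `COc1ccc(S(=O)(=O)c2nc3ccccc3nc2N2CCCC(O)C2)cc1`: 3050 nM

On these numbers, compound 2 stands level with compound 1, as the two values lie within the scatter of each other and cannot be ranked. The next compound to be tested is compound 3 `COc1ccc(S(=O)(=O)c2nc3ccccc3nc2N2CCC(O)CC2)cc1`. Its change from compound 2 is 4-hydroxypiperidin-1-yl in place of 3-hydroxypiperidin-1-yl on an aromatic carbon. The two have the same atoms, joined differently, with 4-hydroxypiperidin-1-yl in place of 3-hydroxypiperidin-1-yl on an aromatic carbon.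

Within the data shown here, only one measured step bears on this, and only indirectly. That step, at the same place on the shared core, is a 1.2-fold lower number from compound 1 to compound 2 (0.08 log units; within the scatter), and it exchanged a different group, 3-hydroxypiperidin-1-yl in place of 1,2,3,4-tetrahydroisoquinolin-2-yl. Among the measured compounds shown here, no measured pair tests a shift of the hydroxy group itself. Even so, with that one step inside the scatter, no step beyond the scatter is expected in this assay, in either direction. The expected step is a 1.0-fold higher number from compound 2 to compound 3 (0.02 log units; within the scatter). For compound 3 the estimated value is 3200 nM, with an expected range of 1500 nM to 6500 nM.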

Compound 3, half-maximal inhibitory concentration: 3230 nM
Beside the measured number, compound 3's estimate is 1.0-fold (0.00 log units) below it; the range from low to high includes it.
By their numbers in this assay, from the lowest: compounds 2, 3 and 1 (each within the scatter of the next).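

In this assay, the first direct test of where the hydroxy group sits on the piperidine ring gives a 1.1-fold higher number from compound 2 to compound 3 (0.02 log units; within the scatter), so 3-hydroxypiperidin-1-yl and 4-hydroxypiperidin-1-yl cannot be told apart on this aromatic carbon next to the ring nitrogen. Set against 1,2,3,4-tetrahydroisoquinolin-2-yl, the second hydroxypiperidine gives a 1.1-fold lower number from compound 1 to compound 3 (0.06 log units; within the scatter), so compound 1, compound 2 and compound 3 now form a single level group, each within the scatter of the others, and none of the three groups can be ranked at this position. Nothing available on these compounds speaks to why the three read alike.

From the compounds shown here alone, whether the hydroxy group itself counts here stays open, a question that a plain piperidin-1-yl set beside compound 2 and compound 3 would address. Also open, going by these compounds, is whether this level holds for groups of another kind at the same carbon, such as an open-chain dimethylamino group, a piperazine or a piperidine bearing a carboxylic acid.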